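The compounds below may be only part of what the source reports. "The series", "measured", "known", "first", "only" and "open" are said of these compounds alone.

Measured compounds in a functional assay on A549 cells (Homo sapiens) for inhibition, read by sulforhodamine B assay; a higher number here means a weaker inhibitor of growth, a lower number a stronger inhibitor of growth:
compound 1 `Oc1cccc2[nH]c(-c3ccc(-c4ccc(-c5ccc(C(F)(F)F)cc5)cc4)cc3)nc12` gives 3610 nM
compound 2 `Oc1cccc2[nH]c(-c3ccc(-c4ccc(-c5ccc(OC(F)(F)F)cc5)cc4)cc3)nc12` gives 190 nM
compound 3 `Cc1ccc2[nH]c(-c3ccc(-c4ccc(-c5ccc(C(F)(F)F)cc5)cc4)cc3)nc2c1` gives 3520 nM

Not yet measured: compound 4 `Cc1ccc2[nH]c(-c3ccc(-c4ccc(-c5ccc(OC(F)(F)F)cc5)cc4)cc3)nc2c1`.

Two cores appear. The difference between the cores of compound 1 and compound 3 is 5-methyl-1H-benzimidazol-2-yl in place of 4-hydroxy-1H-benzimidazol-2-yl on an aromatic carbon; that exchange leaves the number where it is, a 1.0-fold lower number from compound 1 to compound 3 (0.01 log units; within the scatter). On the core of compound 1, the change trifluoromethoxy in place of trifluoromethyl on an aromatic carbon produced a 19-fold lower number from compound 1 to compound 2 (1.28 log units; beyond the scatter). The same change is now to be made on the core of compound 3: trifluoromethoxy in place of trifluoromethyl on an aromatic carbon; the place descriptions match word for word, so it is the same change on the other core. Since compound 1 and compound 3 sit at the same level in this assay a 1.0-fold lower number from compound 1 to compound 3 (0.01 log units; within the scatter), the core exchange is not seen to alter the read-out, and the step is expected to carry over. From compound 3 to compound 4 a step of a 16-fold lower number from compound 3 to compound 4 (1.20 log units; beyond the scatter) is expected, resting on the step from compound 1 to compound 2 a 19-fold lower number from compound 1 to compound 2 (1.28 log units; beyond the scatter). Compound 4 is estimated at 220 nM, with a range from 80 nM to 700 nM. Among the compounds with values here, only one prior instance of this change exists, so the range is set wider than that single step alone would suggest.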

Compound 4, concentration for 50% growth inhibition: 3560 nM
The estimate for compound 4 lay 16-fold (1.21 log units) below the measured number; measured number above the stated range.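

In this assay, the exchange of trifluoromethyl for trifluoromethoxy does not carry from the core of compound 1 to the core of compound 3, where the step is a 1.0-fold higher number from compound 3 to compound 4 (0.00 log units; within the scatter), and the two steps disagree: the same change on two cores in this assay, a 19-fold lower number (1.28 log units; beyond the scatter) from compound 1 to compound 2 and a 1.0-fold higher number (0.00 log units; within the scatter) from compound 3 to compound 4, 19-fold (1.28 log units) apart, beyond the scatter of two such steps. Read the other way, the core exchange that changes nothing with trifluoromethyl in place gives a 19-fold higher number from compound 2 to compound 4 (1.27 log units; beyond the scatter) with trifluoromethoxy in place: the same change on two cores in this assay, a 1.0-fold lower number (0.01 log units; within the scatter) from compound 1 to compound 3 and a 19-fold higher number (1.27 log units; beyond the scatter) from compound 2 to compound 4, 19-fold (1.28 log units) apart, beyond the scatter of two such steps. These four compounds therefore show that the effect of the change depends on the core, with compound 2 alone at 190 nM, but they do not show which part of the core difference matters, as the hydroxy and methyl groups also sit at different places on it.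

From the compounds shown here alone, whether the number of compound 2 depends on the hydroxy group itself stays open, and a core carrying a methoxy group or an amine at that place would bear on it. Also open, going by these compounds, is how other end groups, such as a nitrile or a chlorine, behave on the two cores.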